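A few compounds are considered here, and "the series" means these few. Any claim that something is new, unique, unknown or untested is made for them only; others in the source may bear on it.

The three measured compounds in a functional assay on isolated protein for agonist activity at Glucose-dependent insulinotropic receptor (Rattus norvegicus), read by HTRF and cAMP accumulation; on this read-out higher numbers stand for larger maximal responses and lower numbers for smaller maximal responses:

Compound 1, `CC(C)(C)OC(=O)N1CCC(O[C@H]2CC[C@H](Oc3ccc(S(C)(=O)=O)cc3F)CC2)CC1`, gives 119%.
Compound 2, `CC(C)S(=O)(=O)c1cnc(O[C@H]2CC[C@H](OC3CCN(C(=O)OC(C)(C)C)CC3)CC2)cn1`, gives 128%.
Compound 3, `C[C@H](CF)OC(=O)N1CCC(O[C@H]2CC[C@H](Oc3cnc(S(C)(=O)=O)cn3)CC2)CC1`, gives 115%.

Among these three numbers compound 3 stands lowest. Its nearest neighbour is compound 1, whose number lies within the usual scatter of compound 3, so the two cannot be told apart. Compound 2 lies furthest away, with a number higher than that of compound 3 by more than the scatter allows. No pair of these compounds differs in a single place, so no single structural step can be tied to these values.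

Compound 4, `CS(=O)(=O)c1cnc(O[C@H]2CC[C@H](OC3CCN(CC4(C(F)(F)F)CCCC4)CC3)CC2)cn1`, has not yet been measured. It differs from compound 3 in one place: a group of 10 heavy atoms (7 carbon, 3 fluorine; one five-membered non-aromatic ring of carbon only) in place of a group of 7 heavy atoms (4 carbon, 2 oxygen, 1 fluorine; no ring), on an amine nitrogen in a ring. Among the measured compounds shown here, every measured compound carries a group with oxygen on this ring nitrogen, and all reach a similar maximal response, so there is no measured step to lean on for a change to a group without oxygen. The expected step of a number 3 percentage points lower from compound 3 to compound 4 (within the scatter) is small, within the scatter, with no clear direction. Compound 4 is therefore expected to give about 112% in this assay, estimated between 88% and 136%.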

Compound 4, largest response reached (Emax), in percent of the reference or control that the assay uses: 88%
Beside the measured number, compound 4's estimate is 24 percentage points above it; the range from low to high includes it.
By their numbers in this assay, from the lowest: compound 4; then compounds 3, 1 and 2 (each within the scatter of the next, the first and the last beyond it).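

In this assay, the group on the amine nitrogen in a ring proves able to move the maximal response: the swap gives a number 27 percentage points lower from compound 3 to compound 4 (beyond the scatter). Compound 4 is the only compound shown whose group at this position carries no oxygen, and the entering group, with its five-membered ring of carbon and its three fluorines, has no hydrogen-bond acceptors, while the group it replaces has 2. No accompanying measurement bears on why the response changes with this swap.

The swap changes the oxygens, the ring and the fluorine count all at once, so the step cannot show which of these matters. A cyclopentylmethyl group without fluorine, or an amide carrying the same ring on this nitrogen, would begin to pull these features apart.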